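This account rests on a few compounds, and the source may have more. Where it says the series, first, only, none or still open, it means among the compounds named here.

Measured compounds:
- compound 1 `CCOc1ccc(NC(=O)c2cccc(/C=C3\CC(=O)N(Cc4ccccc4)C3=O)c2)cc1`: 73200 nM
- compound 2 `Cc1ccc(N2C(=O)C/C(=C\c3cccc(C(=O)Nc4cccc(F)c4)c3)C2=O)cc1`: 96900 nM
- compound 3 `CCOc1ccc(NC(=O)c2cccc(/C=C3\CC(=O)N(c4ccccc4)C3=O)c2)cc1`: 91500 nM

All three were run in an ADME assay on SW480 cells (Homo sapiens) for cytotoxicity, read by MTT assay, with a stated time of 72 h; a lower number here means a stronger inhibitor, a higher number a weaker inhibitor. On the numbers alone compound 2 sits at the top of the three, but its gaps to compound 3 and to compound 1 are both within the scatter, so the three cannot be told apart on this read-out.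

The unmeasured compound is compound 4 `CCCCCN1C(=O)C/C(=C\c2cccc(C(=O)Nc3cccc(F)c3)c2)C1=O`. Its difference from compound 2 is pentyl in place of 4-methylphenyl on an amide-type nitrogen in a ring. Among the measured compounds shown here, the one measured step at this same place is a 1.3-fold higher number from compound 1 to compound 3 (0.10 log units; within the scatter), which exchanged one ring-bearing group for another and left the number where it was. For the measured compounds named here, no measured step exchanges a ring-bearing group for a chain, so the pentyl change is uncharted here; the only guide is that the single change at this nitrogen did nothing beyond the scatter.

The expected step is therefore a 1.1-fold lower number from compound 2 to compound 4 (0.03 log units; within the scatter), with no movement beyond the scatter anticipated. For compound 4 the estimate in this assay is 90000 nM, with a range of 40000 nM to 200000 nM.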

Compound 4, half-maximal inhibitory concentration: > 100000 nM
Compound 4: a limit, no number (the forecaster's own chance of this, stated with the estimate: 20%); middle value at least 1.1-fold (0.04 log units) from the limit.
By their numbers in this assay, from the lowest: compounds 1, 3 and 2 (each within the scatter of the next). At a limit, above all of these: compound 4.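

In this assay compound 4 gives > 100000 nM, which is a limit of the assay and not a number. The step reads an at least 1.0-fold higher number from compound 2 to compound 4 (0.01 log units; that floor lies within the scatter), so only a floor is known, and that floor does not separate pentyl from 4-methylphenyl on the amide-type nitrogen in a ring. The new information is that this position has now carried a chain with no ring, and the read-out for that compound is a limit rather than a number: the limit of > 100000 nM in this assay, at which 1 of the 4 values shown sits.

The true distance between the pentyl and 4-methylphenyl compounds remains unresolved, so the effect of losing the ring at this nitrogen cannot be sized. Also open, from the compounds shown here alone, is whether a shorter chain such as ethyl, or a pentyl chain ending in an amine or a carboxylic acid, would give a number within the range of this assay.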